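This account rests on a few compounds, and the source may have more. Where it says the series, first, only, none or still open, it means among the compounds named here.

Working notes on the series, read in a functional assay on A549 cells (Homo sapiens) for antiproliferative activity, read by MTT assay, with a stated time of 48 h; a lower number here means a stronger inhibitor, a higher number a weaker inhibitor. Compound 1 (`C#Cc1cccc(Nc2ncnc3cc(NC(=O)/C=C/c4ccccc4)sc23)c1`) gives 26200 nM, the highest of the three numbers in hand, although compound 3 (`COc1ccc(/C=C/C(=O)Nc2cc3c(Nc4cc(Cl)cc(Cl)c4)ncnc3s2)cc1`), at 21900 nM, lies within the scatter of it. Compound 2 (`O=C(/C=C/c1ccccc1)Nc1cc2c(Nc3ccc(Cl)c(Cl)c3)ncnc2s1`) gives 7600 nM, a lower number that lies beyond the scatter of compound 1.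

Compound 4 (`O=C(/C=C/c1ccccc1)Nc1cc2ncnc(Nc3cc(Cl)cc(Cl)c3)c2s1`) has not been measured. It keeps the rest of compound 1 and changes one group: 3,5-dichlorophenyl in place of 3-ethynylphenyl on a nitrogen on an aromatic ring. In words, 3,5-dichlorophenyl stands in place of 3-ethynylphenyl on a nitrogen on an aromatic ring.

For the measured compounds named here, no measured pair isolates this change, so the size of the step rests on thin evidence. The same 3,5-dichlorophenyl is carried by compound 4 and by a structure that differs from it elsewhere, so the value of compound 3, 21900 nM, is only a rough guide. That value suggests no large move in this assay, and at most a small shift towards a lower number is expected, probably within the scatter. The expected change is a 1.5-fold lower number from compound 1 to compound 4 (0.16 log units; within the scatter). For compound 4 the estimated value is 18000 nM, with an expected range of 7000 nM to 40000 nM.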

Compound 4, half-maximal inhibitory concentration: 12500 nM
Compound 4: middle estimate off by 1.4-fold (0.16 log units), on the high side, within the range that was stated.
By their numbers in this assay, from the lowest: compounds 2, 4, 3 and 1 (each within the scatter of the next, the first and the last beyond it).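

On a nitrogen on an aromatic ring, 3,5-dichlorophenyl in place of 3-ethynylphenyl gives a 2.1-fold lower number from compound 1 to compound 4 (0.32 log units; beyond the scatter) in this assay, and this is the only pair shown that isolates this position. The step is modest but lies beyond the scatter, so the group on this nitrogen can move the number even when the rest of compound 1 is kept and the heavy-atom count, the single carbon-only aromatic ring and the absence of hydrogen-bond donors and acceptors stay the same. No measurement shown bears on why the number moves.

Comparisons of compound 4 with compound 2 or compound 3 cannot be read as single-change steps, as those structures differ from it in more than one place, so this pair says nothing on how the dichlorophenyl pattern or the methoxy group acts alone. Also open, on these data alone, is how the series responds at this position to a phenyl carrying a nitrile, a dimethylamino group or a carboxylic acid, and whether any of these moves the number further than 3,5-dichlorophenyl does.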